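The source may report more compounds than this note shows. Statements on the series, on what has been measured and on what is new or still open speak of the compounds shown alone.

Compound 1 `O=C(NCCCNc1cc(-c2cn(-c3ccccc3)nc2-c2cccc(O)c2)ccn1)Nc1ccc(F)cc1` (7650 nM)
Compound 2 `O=C(NCCCNc1cc(-c2cn(-c3ccccc3)nc2-c2cccc(O)c2)ccn1)Nc1cccc(C(F)(F)F)c1` (9340 nM)

In a functional assay on NCI-H23 cells (Homo sapiens) for antiproliferative activity, read by sulforhodamine B assay, with a stated time of 48 h (on this read-out higher numbers stand for weaker inhibition of growth and lower numbers for stronger inhibition of growth), only these two compounds have been measured, and compound 1 stands within the scatter of compound 2, so neither can be ranked above the other. Compound 3 `COc1cccc(-c2nn(-c3ccccc3)cc2-c2ccnc(NCCCNC(=O)Nc3ccc(F)cc3)c2)c1` differs from compound 1 by one change: methyl in place of hydrogen on an oxygen on an aromatic ring turns hydroxy to methoxy, with 3-methoxyphenyl in place of 3-hydroxyphenyl. For the measured compounds named here, no measured step touches this oxygen. Going by the values given here, the only measured step, a 1.2-fold higher number from compound 1 to compound 2 (0.09 log units; within the scatter), lies on an amide-type nitrogen, so it bears on the new change only loosely and gives no direction. No step beyond the scatter is therefore expected in this assay, though the evidence is thin. The expected step is a 1.1-fold lower number from compound 1 to compound 3 (0.04 log units; within the scatter) and remains within the scatter. For compound 3 the estimated value is 7000 nM, with an expected range from 3000 nM to 16000 nM.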

Compound 3, concentration for total growth inhibition: > 37000 nM
Compound 3 gave a limit, no number (the forecaster's own chance of this, stated with the estimate: 10%); at least 5.2-fold (0.72 log units) between middle value and limit.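

In this assay, the change from 3-hydroxyphenyl to 3-methoxyphenyl is the only one shown whose step lies beyond the scatter, and it goes towards weaker inhibition of growth: an at least 4.8-fold higher number from compound 1 to compound 3 (0.68 log units; beyond the scatter). The one earlier step, on an amide-type nitrogen, stayed within the scatter: a 1.2-fold higher number from compound 1 to compound 2 (0.09 log units; within the scatter), so this oxygen on the aromatic ring is the one place shown where a single change separates two compounds. Compound 3 is recorded only as a limit, not a number, so the full size of its step stays unknown: the limit of > 37000 nM in this assay, at which 1 of the 3 values shown sits.

The compounds shown leave open whether a group such as an amine, a fluorine or a longer ethoxy in place of the hydroxy would give the same loss. They also leave open whether methyl on this oxygen would have the same effect with the 3-(trifluoromethyl)phenyl of compound 2.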